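The source may hold more compounds than are shown below. What is called first, only, known or untested is meant among the compounds shown, and "the series" means these compounds.

Of the compounds shown here, two from this series have been tested in a functional assay on A549 cells (Homo sapiens) for antiproliferative activity, read by MTT assay, with a stated time of 48 h; on this read-out higher numbers stand for weaker inhibition and lower numbers for stronger inhibition. Compound 1 `CCOc1ccccc1-n1nncc1CN1C(=O)C2(C(C#N)=C(N)Oc3c2c2nc4ccccc4nc2c2ccccc32)c2ccccc21` gives > 50000 nM, which is a limit of the assay rather than a measured number; it marks (the limit of > 50000 nM in this assay, at which 1 of the 2 values shown sits). Among the measured compounds shown here, compound 2 `N#CC1=C(N)Oc2c(N)cc3nc4ccccc4nc3c2C12C(=O)N(Cc1cnnn1-c1ccccc1Cl)c1ccccc12` gives 29800 nM in this assay, and this is the only actual number so far. Compound 3 `COc1ccc(OC)c(-n2nncc2CN2C(=O)C3(C(C#N)=C(N)Oc4c(N)cc5nc6ccccc6nc5c43)c3ccccc32)c1` has not yet been measured. It differs from compound 2 in one place: 2,5-dimethoxyphenyl in place of 2-chlorophenyl on an aromatic nitrogen. For the measured compounds named here, no step between two measured compounds is available to calibrate this change, and compound 1, whose result is a limit, carries a different core, so it offers no direct comparison. The expected step from compound 2 to compound 3 is a 1.5-fold higher number from compound 2 to compound 3 (0.18 log units; within the scatter), that is, a shift toward weaker inhibition, though not clearly beyond the usual scatter. Compound 3 is therefore estimated at 45000 nM in this assay, with a range from 15000 nM to 150000 nM, and there is a fair chance that the assay reports only a limit.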

Compound 3, half-maximal inhibitory concentration: 28100 nM
Beside the measured number, compound 3's estimate is 1.6-fold (0.20 log units) above it; low and high end bracket the measured number.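

In this assay, placing 2,5-dimethoxyphenyl where 2-chlorophenyl stood, on an aromatic nitrogen of the five-membered ring with 3 nitrogen, gives a 1.1-fold lower number from compound 2 to compound 3 (0.03 log units; within the scatter). Among the compounds shown here, this is the only step that joins two real numbers, and it shows that this exchange leaves the read-out unchanged within the usual scatter, so compound 2 and compound 3 cannot be told apart here. That holds even though the exchange swaps a chlorine for two oxygens, raises the group from 7 to 10 heavy atoms and brings 2 hydrogen-bond acceptors where the leaving group had 0.

As far as these compounds go, compound 1 offers no further comparison, as its result is a limit and not a number and its core differs: the limit of > 50000 nM in this assay, at which 1 of the 3 values shown sits. Still open is whether a different group on the same aromatic nitrogen, such as a phenyl ring carrying an amine or a carboxylic acid, or a longer chain in place of the phenyl ring, would move the number beyond the scatter.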